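The compounds below may be only part of what the source reports. "The series", "measured", "known", "first", "only" and "open" are said of these compounds alone.

Measured so far in a functional assay on the whole organism for inhibition, with Digitaria ciliaris as the target, with a stated time of 72 h, tested at 100 mg/L; a higher number here means more inhibition of growth at the concentration tested, a lower number less inhibition of growth:

Compound 1 `CSc1cc(C)nc(NC(=S)NC(=O)c2c(-c3ccc(Cl)cc3Cl)noc2C)n1`: 45.5%
Compound 2 `Cc1cc(Cl)nc(NC(=S)NC(=O)c2c(-c3ccc(Cl)cc3Cl)noc2C)n1`: 44.2%
Compound 3 `COc1cc(Cl)nc2n/c(=N/C(=O)c3c(-c4ccc(Cl)cc4Cl)noc3C)sn12`: 72.8%

Compound 1 and compound 2 share a core; compound 1 differs from compound 2 by methylsulfanyl in place of chloro on an aromatic carbon. That change gave a number 1.3 percentage points higher from compound 2 to compound 1 (within the scatter). Compound 3 carries a different core; the difference between the two cores is not broken down here. Compound 3 stands highest of the three, with compound 1 and compound 2 both beyond the scatter below it.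

Compound 4 `COc1cc(SC)nc2n/c(=N/C(=O)c3c(-c4ccc(Cl)cc4Cl)noc3C)sn12` is not yet measured. It differs from compound 3 by methylsulfanyl in place of chloro on an aromatic carbon. This is the same kind of change as from compound 2 to compound 1, but the place is not the same: in compound 4 the ring is part of a fused or bridged system of two rings, the group is meta to a fused ring, meta to a methoxy group and para to a fused ring, whereas in compound 1 it is meta to a large group and meta to a methyl group.

In this assay a step of a number 0.2 percentage points higher from compound 3 to compound 4 (within the scatter) is expected, because the same kind of change gave a number 1.3 percentage points higher from compound 2 to compound 1 (within the scatter). Compound 4 is therefore estimated at 73%, between 58% and 86%.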

Compound 4, percent growth inhibition at one concentration: 79.6%
For compound 4 the middle estimate is 6.6 percentage points below the measured one; the measured number falls inside the stated range.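

In this assay, methylsulfanyl in place of chloro on an aromatic carbon gave a number 6.8 percentage points higher from compound 3 to compound 4 (within the scatter). Set beside the earlier step, the change reads the same on both cores: the same change on two cores in this assay, a number 1.3 percentage points higher (within the scatter) from compound 2 to compound 1 and a number 6.8 percentage points higher (within the scatter) from compound 3 to compound 4, 5.5 percentage points apart, within the scatter of two such steps. The swap can therefore be carried between these two cores without a measurable shift in growth inhibition at the one tested concentration, but two pairs do not show that it would stay neutral on any other core, and neither step shows a real gain or loss from the change.

Still open, going by these compounds, is whether a different group on that aromatic carbon, such as an amine, a methoxy group or a longer sulfur-linked chain, would move growth inhibition beyond the scatter on either core. Also open is whether the methoxy group on the core of compound 3 and compound 4 contributes to their readings, since no compound shown changes that group alone.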